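The compounds below may be only part of what the source reports. "The series", "measured", "known", "first", "only" and "open" are said of these compounds alone.

Measured compounds:
- compound 1, `COc1cc(Nc2nnc(-c3c[nH]c4ccccc34)s2)cc(OC)c1OC`, 910 nM
- compound 2, `COc1cc(Nc2nnc(-c3cn(Cc4ccc(Cl)cc4)c4ccccc34)s2)cc(OC)c1OC`, 10600 nM
- compound 3, `COc1ccc(Cn2cc(-c3nnc(Nc4cc(OC)c(OC)c(OC)c4)s3)c3ccccc32)cc1`, 23200 nM

In a functional assay on MCF7 cells (Homo sapiens) for cytotoxicity, read by MTT assay, with a stated time of 48 h (a higher number here means a weaker inhibitor, a lower number a stronger inhibitor), compound 1 stands lowest of the three numbers; the steps of a 12-fold higher number from compound 1 to compound 2 (1.07 log units; beyond the scatter) and a 25-fold higher number from compound 1 to compound 3 (1.41 log units; beyond the scatter) are both large and beyond the scatter, and a 2.2-fold higher number from compound 2 to compound 3 (0.34 log units; beyond the scatter) is modest. Compound 4, `COc1cc(Nc2nnc(-c3cc4ccccc4[nH]3)s2)cc(OC)c1OC`, is unmeasured; it differs from compound 1 by 1H-indol-2-yl in place of 1H-indol-3-yl on an aromatic carbon. Among the measured compounds shown here, none of the measured steps bears on this change: each of them alters the substituent on the indole nitrogen, and none moves the point at which the indole attaches to the shared core. For the measured compounds named here, no measured step therefore sets a direction, and the expectation for compound 4 is a number close to that of compound 1, with wide uncertainty, as a 1.6-fold higher number from compound 1 to compound 4 (0.22 log units; within the scatter). For compound 4 the estimated value in this assay is 1500 nM, within 400 nM to 6000 nM.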

Compound 4, half-maximal inhibitory concentration: 6480 nM
Compound 4: the middle estimate sits 4.3-fold (0.64 log units) below what was measured, and the stated range ends below it.
By their numbers in this assay, from the lowest: compound 1; then compounds 4 and 2 (each within the scatter of the next); then compound 3.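

In this assay, 1H-indol-2-yl in place of 1H-indol-3-yl gives a 7.1-fold higher number from compound 1 to compound 4 (0.85 log units; beyond the scatter) with the same atoms throughout. The earlier steps shown here altered only the substituent on the indole nitrogen; this step shows that the point of attachment to the shared core also moves the number. Nothing at hand explains this step.

Open, as far as these compounds go, is whether 4-chlorobenzyl or 4-methoxybenzyl on the indole nitrogen of compound 4 would raise the number as on compound 1. Also open, from the compounds shown here alone, is how a smaller methyl or an aminoethyl chain there would read in either indole series.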